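Lengthening the Alkoxy Chain on a Shared Core

This account rests on a few compounds, and the source may have more. Where it says the series, first, only, none or still open, it means among the compounds named here.

Compound 1 `C[S+]([O-])/C=C/c1cc(=O)c2ccccc2o1`: 8000 nM
Compound 2 `COc1ccc2oc(/C=C/[S+](C)[O-])cc(=O)c2c1`: 5700 nM

Both compounds were tested in a functional assay on DLD-1 cells (Homo sapiens) for cytotoxicity, with a stated time of 48 h; on this read-out lower numbers stand for stronger inhibition and higher numbers for weaker inhibition. Among the measured compounds shown here, compound 2 holds the lower of the two numbers, but the only measured step, a 1.4-fold lower number from compound 1 to compound 2 (0.15 log units; within the scatter), lies within the scatter, so the two cannot be ranked. Compound 3 `CCCCOc1ccc2oc(/C=C/[S+](C)[O-])cc(=O)c2c1` differs from compound 2 by propyl in place of hydrogen on a saturated chain carbon bound to an oxygen on an aromatic ring. For the measured compounds named here, no measured step covers a change of this kind; the one known step, adding methoxy in place of hydrogen, moved little. A step of at most modest size in either direction is therefore expected. Compound 3 is estimated at 4500 nM (range 1500 nM to 13000 nM), an expected 1.3-fold lower number from compound 2 to compound 3 (0.10 log units; within the scatter).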

Compound 3, half-maximal inhibitory concentration: 4800 nM
Beside the measured number, compound 3's estimate is 1.1-fold (0.03 log units) below it, and the stated range covers the measured number.
By their numbers in this assay, from the lowest: compounds 3, 2 and 1 (each within the scatter of the next).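

Lengthening methoxy to butoxy gives, in this assay, a 1.2-fold lower number from compound 2 to compound 3 (0.07 log units; within the scatter), so a chain of this length on the saturated chain carbon bound to an oxygen on an aromatic ring can be carried without a change that can be told from the scatter. Adding the whole butoxy group to the shared core gives a 1.7-fold lower number from compound 1 to compound 3 (0.22 log units; within the scatter), which also stays within the scatter. Nothing available explains why the number stays so flat. Still open, on these data alone, is whether a longer chain, or an amine or a carboxylic acid at the end of the butoxy chain, would move the number beyond the scatter.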